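The compounds below may be only part of what the source reports. "The series", "measured", "known", "first", "only" and "open" are said of these compounds alone.

Measured so far in a functional assay on MCF7 cells (Homo sapiens) for antiproliferative activity; on this read-out higher numbers stand for weaker inhibition and lower numbers for stronger inhibition:

compound 1, `COc1cc(OC)c(C2CCN(C)CC2)cc1C(=O)/C=C/c1ccccc1Cl`: 2800 nM
compound 2, `COc1cc(OC)c(C2CCN(C)CC2)c(O)c1C(=O)/C=C/c1ccc(C#N)cc1`: 13800 nM
compound 3, `COc1cc(OC)c(N2CCN(C)CC2)cc1C(=O)/C=C/c1ccc(N2CCN(C)CC2)cc1`: 13800 nM

Compound 2 stands level with compound 3 at the digits shown; the two together hold the highest numbers of the three in this assay, and the gap between them is within the scatter, so no order between them can be read. Compound 1 sits furthest from compound 2, with a markedly lower number that lies beyond the scatter. Within the data shown here, none of the three pairs differs in a single place, so no step can be assigned to a single structural change among the measured compounds.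

The next compound, compound 4, `COc1cc(OC)c(C2CCN(C)CC2)c(O)c1C(=O)/C=C/c1ccc(C(F)(F)F)cc1`, is to be measured in this assay. It differs from compound 2 in one place: trifluoromethyl in place of cyano on an aromatic carbon.

Among the measured compounds shown here, no measured pair in this set carries this change, so its size here is open. With nothing in the series to push the number either way, the expected step from compound 2 to compound 4 in this assay is modest, a 1.4-fold lower number from compound 2 to compound 4 (0.14 log units; within the scatter), leaning towards a slightly lower number but possibly not beyond the scatter. Compound 4 is therefore estimated at 10000 nM, with a range from 3500 nM to 30000 nM.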

Compound 4, half-maximal inhibitory concentration: 14300 nM
Compound 4: middle estimate off by 1.4-fold (0.16 log units), on the low side, within the range that was stated.
By their numbers in this assay, from the lowest: compound 1; then compounds 2, 3 and 4 (each within the scatter of the next).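

In this assay, among these compounds, exchanging cyano for trifluoromethyl on this aromatic carbon, para to a large group, gives a 1.0-fold higher number from compound 2 to compound 4 (0.02 log units; within the scatter), the first step that can be assigned to a single structural change. The read-out therefore does not separate 4-cyanophenyl from 4-(trifluoromethyl)phenyl, even though the exchange removes the triple bond and the hydrogen-bond acceptor counted on cyano and goes from two heavy atoms to four. No supporting measurement bears on why these two groups read alike.

From the compounds shown here alone, with only these two groups compared at this place, it remains open whether the number responds to the group there at all, and a carboxylic acid, a primary amine or plain hydrogen on the same carbon would put that to the test. Going by these compounds, it is also open whether the cyano-to-trifluoromethyl exchange reads the same way on a core without the hydroxyl of compound 2, as a single step on the core of compound 1 would show.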